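From cyclopropyl to 1-methoxyethyl on the shared core

This account rests on a few compounds, and the source may have more. Where it says the series, first, only, none or still open, it means among the compounds named here.

In a functional assay on OCI-Ly3 cells (Homo sapiens) for antiproliferative activity (on this read-out lower numbers stand for an effect already at smaller amounts and higher numbers for an effect only at larger amounts of compound), compound 3 (`O=C(Nc1cnc(-n2nccn2)c(Cl)c1)Nc1cnc2ccccc2c1C1CC1`) gives 1580 nM. Compound 1 (`CC(C)c1c(NC(=O)Nc2cnc(-n3nccn3)c(Cl)c2)cnc2ccccc12`) gives 2420 nM, and the two stand level: a 1.5-fold lower number from compound 1 to compound 3 (0.19 log units; within the scatter). Compound 2 (`O=C(Nc1cnc(-n2nccn2)c(Cl)c1)Nc1cnc2ccccc2c1C1CCCC1`) gives 7020 nM, clearly apart: a 4.4-fold lower number from compound 2 to compound 3 (0.65 log units; beyond the scatter).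

Compound 4 (`COC(C)c1c(NC(=O)Nc2cnc(-n3nccn3)c(Cl)c2)cnc2ccccc12`) carries 1-methoxyethyl in place of cyclopropyl on an aromatic carbon. Going by the values given here, none of the measured groups has a hydrogen-bond acceptor, so the data do not cover that feature directly. Isopropyl is the measured group closest to the incoming one, as neither has a ring, and the step that bears most directly is a 1.5-fold lower number from compound 1 to compound 3 (0.19 log units; within the scatter). The step to cyclopentyl also bears on it, as a modest one towards higher numbers: a 2.9-fold higher number from compound 1 to compound 2 (0.46 log units; beyond the scatter).

A small move towards a higher number in this assay is therefore expected, probably within the scatter. For compound 4 the expected step is a 1.8-fold higher number from compound 3 to compound 4 (0.25 log units; within the scatter). The estimated value for compound 4 is 2800 nM, with an expected range of 1100 nM to 7000 nM.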

Compound 4, half-maximal effective concentration: 620 nM
Estimate against measurement, compound 4: 4.5-fold (0.65 log units) above; the whole stated range lies above it.
By their numbers in this assay, from the lowest: compound 4; then compounds 3 and 1 (each within the scatter of the next); then compound 2.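

Going by these compounds alone, at this position, opposite the ring nitrogen, 1-methoxyethyl is the first group carrying a hydrogen-bond acceptor, and it gives the lowest number of the series in this assay: a 2.5-fold lower number from compound 3 to compound 4 (0.41 log units; beyond the scatter), and an 11-fold lower number from compound 2 to compound 4 (1.05 log units; beyond the scatter). The closest comparison changes only methoxy in place of methyl on the saturated chain carbon, and that alone moves the number beyond the scatter: a 3.9-fold lower number from compound 1 to compound 4 (0.59 log units; beyond the scatter). Nothing available here explains this shift.

As far as these compounds go, with a single oxygen-bearing group in the set, it remains open whether the lower number extends to other groups carrying oxygen at this position or is specific to 1-methoxyethyl. A 1-hydroxyethyl group, a methoxymethyl group or a longer ether chain would test this, and a dimethylaminomethyl group would show whether an amine nitrogen behaves similarly.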